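This account rests on a few compounds, and the source may have more. Where it says the series, first, only, none or still open, it means among the compounds named here.

Measured compounds:
- Compound 1 `OCc1cc(CN2CCN(c3ccccc3Oc3ccccc3)CC2)on1`: 3060 nM
- Compound 2 `O=C1CCCCN1Cc1cc(CN2CCN(c3ccccc3Oc3ccccc3)CC2)on1`: 170 nM

In an assay on isolated protein for displacement of a labelled ligand from Alpha-1D adrenergic receptor (Homo sapiens) (on this read-out lower numbers stand for stronger inhibition and higher numbers for weaker inhibition), compound 2 gives 170 nM, the lowest of the two numbers recorded so far. Its nearest neighbour is compound 1, and the step of an 18-fold lower number from compound 1 to compound 2 (1.26 log units; beyond the scatter) shows how far apart they lie: replacing a hydroxy group with a 2-oxopiperidin-1-yl ring produced a large gain. Compound 3 `O=C1CCCCCN1Cc1cc(CN2CCN(c3ccccc3Oc3ccccc3)CC2)on1` has not been measured yet; it differs from compound 2 only in 2-oxoazepan-1-yl in place of 2-oxopiperidin-1-yl on a saturated chain carbon bound to an aromatic carbon, that is, the lactam ring grows from six to seven members while keeping the same single hydrogen-bond acceptor and no donor.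

For the measured compounds named here, no measured step covers a ring enlargement of this kind. Going by the values given here, the one step available, an 18-fold lower number from compound 1 to compound 2 (1.26 log units; beyond the scatter), concerns installing the lactam, not resizing it, so it offers only a loose guide. Since the acceptor and the attachment point are unchanged, the expected effect is modest, and a step of a 1.2-fold higher number from compound 2 to compound 3 (0.07 log units; within the scatter) within the usual scatter is expected. Compound 3 is therefore estimated at 200 nM, with a plausible range from 60 nM to 650 nM.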

Compound 3, inhibition constant: 285 nM
Compound 3: middle estimate off by 1.4-fold (0.15 log units), on the low side, within the range that was stated.
By their numbers in this assay, from the lowest: compounds 2 and 3 (each within the scatter of the next); then compound 1.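

In this assay, putting 2-oxoazepan-1-yl in place of 2-oxopiperidin-1-yl gives a 1.7-fold higher number from compound 2 to compound 3 (0.22 log units; within the scatter), so on this saturated chain carbon bound to an aromatic carbon, the six-membered and seven-membered lactam rings cannot be told apart. The large gain over the hydroxy group also does not belong to the six-membered ring alone: alongside an 18-fold lower number from compound 1 to compound 2 (1.26 log units; beyond the scatter), the seven-membered ring gives an 11-fold lower number from compound 1 to compound 3 (1.03 log units; beyond the scatter), so both lactams shown stand well clear of the hydroxy compound. Nothing available gives a reason for either of these results.

The compounds shown leave open how far the ring size can move in the other direction, and a smaller 2-oxopyrrolidin-1-yl ring at the same place would test this. They also leave open whether the gain over the hydroxy group depends on the carbonyl, the ring or both, a question that a piperidin-1-yl amine, which has the ring without the carbonyl, and an open-chain acetamide, which has the carbonyl without the ring, could help to separate.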